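Methyl and chloro variants of one core: tolerated concentration

The compounds below may be only part of what the source reports. "The series", "measured", "known", "first", "only" and "open" are said of these compounds alone.

Compound 1 `O[C@@H]1Cc2ccccc2N[C@H](c2ccccc2)C1` is the parent of the set. In an ADME assay on THP-1 cells (Homo sapiens) for cytotoxicity, read by MTT assay, with a stated time of 72 h (a lower number here means that less compound is tolerated, a higher number that more compound is tolerated), compound 1 gives > 300000 nM, which is a limit of the assay rather than a number. Compound 2 `Cc1cccc([C@@H]2C[C@H](O)Cc3ccccc3N2)c1` carries methyl in place of hydrogen on an aromatic carbon. In this assay compound 2 gives 176000 nM, and the step of an at least 1.7-fold lower number from compound 1 to compound 2 (0.23 log units; that floor lies within the scatter) is small. Compound 3 `O[C@@H]1Cc2ccccc2N[C@H](c2ccccc2Cl)C1` differs from compound 1 by chloro in place of hydrogen on an aromatic carbon. In this assay compound 3 gives > 300000 nM, again a limit. The step that the two limits leave unreadable from compound 1 to compound 3 cannot be read because of the limit of > 300000 nM in this assay, at which 2 of the 3 values shown sit. Compound 4 `Cc1ccc2c(c1)C[C@@H](O)C[C@@H](c1ccccc1Cl)N2` adds methyl in place of hydrogen on an aromatic carbon to compound 3, the same kind of change as from compound 1 to compound 2, though here the place is part of a fused or bridged system of two rings, meta to a fused ring and para to a fused ring, rather than meta to a large group. A step of an at least 1.2-fold lower number from compound 3 to compound 4 (0.07 log units; that floor lies within the scatter) is expected, resting on the measured step of an at least 1.7-fold lower number from compound 1 to compound 2 (0.23 log units; that floor lies within the scatter). Compound 4 is accordingly estimated at 250000 nM, between 120000 nM and 500000 nM.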

Compound 4, half-maximal cytotoxic concentration: 85200 nM
Estimate against measurement, compound 4: 2.9-fold (0.47 log units) above; measured number below the stated range.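

In this assay, methyl in place of hydrogen on an aromatic carbon gives an at least 3.5-fold lower number from compound 3 to compound 4 (0.54 log units; beyond the scatter), a floor and not a full size. Set beside the same change on the other core, this does not establish a step of different size: the same change on two cores in this assay, an at least 1.7-fold lower number (0.23 log units; that floor lies within the scatter) from compound 1 to compound 2 and an at least 3.5-fold lower number (0.54 log units; beyond the scatter) from compound 3 to compound 4; the limit leaves it open whether they differ. The methyl of compound 4 also sits on the fused system of two rings, so a difference of core cannot be separated from a difference of place, and both steps remain floors because compound 1 and compound 3 stand at a limit: the limit of > 300000 nM in this assay, at which 2 of the 4 values shown sit.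

Open, going by these compounds, is whether methyl at the place it holds in compound 2 would give a comparable step on the core of compound 3. Also open, on these data alone, is how an amine, a carboxylic acid or a longer chain at the place of this methyl would read in this assay.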